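A few compounds are considered here, and "the series" means these few. Any claim that something is new, unique, unknown or untested is made for them only; others in the source may bear on it.

In a functional assay on HCT-116 cells (Homo sapiens) for cytotoxicity, read by MTT assay, with a stated time of 72 h (a lower number here means a stronger inhibitor, a higher number a weaker inhibitor), compound 1 `COc1ccc(C(=O)n2c(C3CCCCC3)nc3ccccc32)cc1` gives > 10000 nM, which is a limit of the assay and not a number. Compound 2 `COc1ccc(C(=O)n2c(C3CCCC3)nc3ccccc32)cc1` gives > 10000 nM, also only a limit. Compound 2 therefore has no exact position in the series, and the data so far show (the limit of > 10000 nM in this assay, at which 2 of the 2 values shown sit).

The next structure is compound 3 `COc1ccc(C(=O)n2c(-c3ccc(OC)cc3)nc3ccccc32)cc1`: 4-methoxyphenyl in place of cyclopentyl on an aromatic carbon. Here 4-methoxyphenyl replaces cyclopentyl on an aromatic carbon of the five-membered aromatic ring with 2 nitrogen, between two ring nitrogen atoms.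

For the measured compounds named here, the only measured step bearing on this change is a step that the two limits leave unreadable from compound 1 to compound 2. It replaces one non-aromatic ring with another and has no readable size, so it cannot set the size of a change to an aromatic ring. Given a step that the two limits leave unreadable from compound 1 to compound 2, the data do not fix a direction, and only a modest move toward stronger inhibition, if any, is expected in this assay. The expected step is an at least 1.1-fold lower number from compound 2 to compound 3 (0.04 log units; that floor lies within the scatter). For compound 3 the estimated value is 9000 nM, with an expected range of 3000 nM to 20000 nM.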

Compound 3, half-maximal inhibitory concentration: > 10000 nM
Compound 3: only a limit was reported (the forecaster's own chance of this, stated with the estimate: 55%); at least 1.1-fold (0.04 log units) between middle value and limit.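

In this assay compound 3 gives > 10000 nM, which is a limit of the assay and not a number. No step among compound 1, compound 2 and compound 3 can be read: the limit of > 10000 nM in this assay, at which 3 of the 3 values shown sit.

The compounds shown leave open whether any group at this place on the shared core gives a measurable value in this assay.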